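The compounds below may be only part of what the source reports. "The series", "measured", "known", "first", "only" and "open" are said of these compounds alone.

Working notes on the series in a toxicity assay on NIH3T3 cells (Mus musculus) for cytotoxicity, read by resazurin assay; on this read-out higher numbers stand for an effect only at larger amounts of compound and lower numbers for an effect already at smaller amounts. Compound 1 (`Clc1ccc(NCc2cncn2Cc2ccc(-c3ccccc3)cc2)cc1-c1ccccc1`) reads > 1000 nM, which is a limit and not a number. Compound 2 (`Nc1cc(-c2ccccc2)ccc1Cn1cncc1CNc1ccc(Cl)c(-c2ccccc2)c1`) reads > 1000 nM, which is also a limit. From the compounds shown here alone, compound 2 thus stands at the limit of > 1000 nM in this assay, at which 2 of the 3 values shown sit, and its exact place is unknown. Within the data shown here, compound 3 (`COC(=O)c1ccc(NCc2cncn2Cc2ccccc2Cl)cc1-c1ccccc1`) is the one compound with a true number, 10000 nM.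

The next compound is compound 4 (`Nc1cc(-c2ccccc2)ccc1Cn1cncc1CNc1ccc(-c2nc3ccccc3s2)c(-c2ccccc2)c1`), with 1,3-benzothiazol-2-yl in place of chloro on an aromatic carbon.

Among the measured compounds shown here, only one measured step is available, a step that the two limits leave unreadable from compound 1 to compound 2. It concerns amino in place of hydrogen, not the group changed here, and it gives no size to carry over. For the measured compounds named here, no measured step replaces chloro, so the data fix neither the size nor the direction of this change. The only level to work from is compound 3 at 10000 nM, though it differs from compound 2 in more than one place and so gives a level and not a step. A reading that is again only a limit in this assay is about as likely as a number. The expected step is a step that the limit leaves unreadable from compound 2 to compound 4. Compound 4 is estimated at 4000 nM, with an expected range of 1000 nM to 15000 nM.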

Compound 4, half-maximal effective concentration: > 1000 nM
Compound 4 gave a limit, no number (the forecaster's own chance of this, stated with the estimate: 50%); the middle value is on the limit's open side.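

In this assay compound 2 and compound 4 both read as limits and not as numbers, so no step can be read between them, and the picture of the series stays as follows: the limit of > 1000 nM in this assay, at which 3 of the 4 values shown sit.

The compounds shown leave open where the true values of compound 2 and compound 4 lie, and whether 1,3-benzothiazol-2-yl in place of chloro shifts the read-out at all.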